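From Amino to Pyrrolidin-1-yl: a Weaker Binder Expected

This account rests on a few compounds, and the source may have more. Where it says the series, first, only, none or still open, it means among the compounds named here.

Of the compounds shown here, three have been measured in an assay on brain for displacement of a labelled ligand from Neuronal acetylcholine receptor; alpha4/beta2 (Rattus norvegicus); a higher number here means a weaker inhibitor, a lower number a stronger inhibitor. Compound 2 `NC1(COc2cccnc2)CC1` gives 34 nM, the lowest of the three numbers; compound 1 `CN(C)C1(COc2cccnc2)CC1` gives 95 nM, and compound 3 `Cc1ccc(OCC2(N)CC2)cn1` gives 266 nM. Compound 4 `c1cncc(OCC2(N3CCCC3)CC2)c1` differs from compound 2 by pyrrolidin-1-yl in place of amino on a saturated ring carbon. The measured step that bears on this change is a 2.8-fold lower number from compound 1 to compound 2 (0.45 log units; beyond the scatter), which replaced a nitrogen without a hydrogen-bond donor by one with such a donor; the step of a 7.8-fold higher number from compound 2 to compound 3 (0.89 log units; beyond the scatter) concerns another part of the structure. Compound 4 again carries a nitrogen without a hydrogen-bond donor on that carbon, so a rise in number of about that size, beyond the scatter, is expected in this assay, namely a 4.4-fold higher number from compound 2 to compound 4 (0.64 log units; beyond the scatter). Compound 4 is therefore estimated at 150 nM, within a range from 50 nM to 450 nM.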

Compound 4, inhibition constant: 1610 nM
Beside the measured number, compound 4's estimate is 11-fold (1.03 log units) below it, and the stated range ends below it.
By their numbers in this assay, from the lowest: compound 2; then compound 1; then compound 3; then compound 4.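

On this saturated ring carbon, the change to pyrrolidin-1-yl gives a 47-fold higher number from compound 2 to compound 4 (1.68 log units; beyond the scatter), so the position tolerates the new group far less well than the earlier step to dimethylamino suggested. Lacking a hydrogen-bond donor on that nitrogen therefore does not set the size of the change, since pyrrolidin-1-yl also stands well apart from dimethylamino, with a 17-fold higher number from compound 1 to compound 4 (1.23 log units; beyond the scatter). No measurement offered here accounts for that gap. The compounds shown leave open how methylamino, azetidin-1-yl or piperidin-1-yl would fare at this place in this assay.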